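The compounds below may be only part of what the source reports. "The series", "measured", "known", "first", "only" and "open" are said of these compounds alone.

Measured in an assay on HEK293 cells for inhibition of Voltage-dependent T-type calcium channel subunit alpha-1G (Homo sapiens), read by fluorescence, tested at 10 uM; a lower number here means less inhibition, a higher number more inhibition at the concentration tested (going by the name of the read-out):
compound 1 `CCCc1nc(-c2ccccc2)c(CNCCN2CCN(c3ccc(Cl)cc3)CC2)o1`, 55.8%
compound 2 `CCCc1nc(-c2ccccc2)c(CNCCCN2CCN(c3ccc(C(F)(F)F)cc3)CC2)o1`, 51.6%
compound 3 `CCCc1nc(-c2ccccc2)c(CNCCCN2CCN(c3cccc(C)c3C)CC2)o1`, 55.2%

Compound 1 stands highest of the three numbers, yet compound 3 and compound 2 both lie within the scatter of it, so none of the three is set apart. Compound 4 `CCCc1nc(-c2ccccc2)c(CNCCN2CCN(c3ccccc3C)CC2)o1` is unmeasured; it differs from compound 1 by 2-methylphenyl in place of 4-chlorophenyl on an amine nitrogen in a ring. Among the measured compounds shown here, the one measured step bearing on this is the swap of the group on the same ring nitrogen, a number 3.6 percentage points higher from compound 2 to compound 3 (within the scatter), which stayed within the scatter, though the linker in that pair differs from that of compound 1. Swapping the aryl group on the ring nitrogen is therefore expected to give no step beyond the scatter in this assay. Compound 4 is estimated at 54%, range 40% to 68%. The expected step is a number 1.8 percentage points lower from compound 1 to compound 4 (within the scatter).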

Compound 4, a percentage reported as inhibition, at one concentration (the size of the read-out at that concentration, not a potency): 51.3%
Compound 4: middle estimate off by 2.7 percentage points, on the high side; low and high end bracket the measured number.
By their numbers in this assay, from the lowest: compounds 4, 2, 3 and 1 (each within the scatter of the next).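

In this assay, 2-methylphenyl in place of 4-chlorophenyl gives a number 4.5 percentage points lower from compound 1 to compound 4 (within the scatter) and shows that an aryl swap on this ring nitrogen stays within the scatter on a second linker as well. Chlorine on the aryl ring is therefore not needed to keep the read-out in this range for this pair. Nothing at hand explains the step.

Still open, going by these compounds, is whether a non-aryl group on this ring nitrogen, such as a benzyl or an acetyl group, would move the number beyond the scatter. On these data alone, the effect of a carboxylic acid on the aryl ring also remains open.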